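This account rests on a few compounds, and the source may have more. Where it says the series, first, only, none or still open, it means among the compounds named here.

Working notes on the series. In a functional assay on MKN-74 cells (Homo sapiens) for antiproliferative activity, with a stated time of 24 h (a lower number here means a stronger inhibitor, a higher number a weaker inhibitor), compound 1 `NC(=O)c1c(NC(=O)c2ccccc2Cl)sc2c1CCNC2` gives 28700 nM, the highest of the three numbers recorded so far. Compound 2 `NC(=O)c1c(NC(=O)c2ccccc2Cl)sc2c1CCN(C(=S)Nc1ccccc1)C2` gives 15600 nM, and compound 3 `NC(=O)c1c(NC(=O)c2ccccc2Cl)sc2c1CCN(C(=S)Nc1ccccc1F)C2` gives 12600 nM. The step of a 1.8-fold lower number from compound 1 to compound 2 (0.26 log units; within the scatter) and the step of a 2.3-fold lower number from compound 1 to compound 3 (0.36 log units; beyond the scatter) both arise from a group placed on the amine nitrogen in the ring of the shared core, while the step of a 1.2-fold lower number from compound 2 to compound 3 (0.09 log units; within the scatter) separates the two substituted compounds from each other.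

Compound 4 `CSc1ccccc1NC(=S)N1CCc2c(sc(NC(=O)c3ccccc3Cl)c2C(N)=O)C1` differs from compound 1 by a group of 11 heavy atoms (8 carbon, 1 nitrogen, 2 sulfur; one six-membered aromatic ring of carbon only) in place of a hydrogen atom, on an amine nitrogen in a ring. The change is of the same kind as in the two measured steps, a group entering on the same amine nitrogen in a ring, with the aromatic ring again carrying a substituent. Those two steps bear directly on it: one within the scatter, the other modestly beyond it. A step of similar size is therefore expected in this assay, toward a lower number, and the data give no ground for anything larger. The expected step is a 2.2-fold lower number from compound 1 to compound 4 (0.34 log units; beyond the scatter). Compound 4 is estimated to give 13000 nM, within a range from 6000 nM to 30000 nM.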

Compound 4, half-maximal inhibitory concentration: 13800 nM
Beside the measured number, compound 4's estimate is 1.1-fold (0.03 log units) below it; low and high end bracket the measured number.
By their numbers in this assay, from the lowest: compounds 3, 4, 2 and 1 (each within the scatter of the next, the first and the last beyond it).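

In this assay, methylsulfanyl on the aromatic carbon does not separate compound 4 from the other two substituted compounds: a 1.1-fold lower number from compound 2 to compound 4 (0.05 log units; within the scatter) for methylsulfanyl in place of hydrogen, and a 1.1-fold higher number from compound 3 to compound 4 (0.04 log units; within the scatter) for methylsulfanyl in place of fluoro. Hydrogen, fluoro and methylsulfanyl are therefore not told apart at this aromatic carbon, a reading that previously rested on the single fluoro step, while a 2.1-fold lower number from compound 1 to compound 4 (0.32 log units; beyond the scatter) gives a second case, after compound 3, of a group on the amine nitrogen in a ring lying modestly beyond the scatter, with compound 2 going against this by staying within it. No measured evidence accompanies these compounds to account for the numbers.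

From the compounds shown here alone, whether an amine or a carboxylic acid on the aromatic ring would stand apart from these three substituted compounds remains open. Also open, going by these compounds, is whether a carbonyl in place of the thiocarbonyl, or a longer alkyl chain in place of the aromatic ring, would keep the number of the substituted compounds or return it toward that of compound 1.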